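Thiophen-3-yl in place of pyridin-3-yl in the series

This account rests on a few compounds, and the source may have more. Where it says the series, first, only, none or still open, it means among the compounds named here.

In an ADME assay on microsomes from liver (Rattus norvegicus) for metabolic stability, read by LC-MS, using NADPH, with a stated time of 90 min, tested at 1 uM (on this read-out lower numbers stand for a shorter-lived compound and higher numbers for a longer-lived compound), compound 1 `Cn1cc(-c2cc(F)ccc2N2CCN(CCCc3c[nH]c4ccc(F)cc34)CC2)cn1` gives 0.158 h and compound 2 `Fc1ccc(N2CCN(CCCc3c[nH]c4ccc(F)cc34)CC2)c(-c2cccnc2)c1` gives 0.0967 h. Among the compounds with values here, these are the only two numbers so far, and they lie within the scatter of each other.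

Compound 3 `Fc1ccc(N2CCN(CCCc3c[nH]c4ccc(F)cc34)CC2)c(-c2ccsc2)c1` has thiophen-3-yl in place of pyridin-3-yl on an aromatic carbon. Within the data shown here, no compound with thiophen-3-yl has been measured. Among the measured compounds shown here, one measured step bears on this change, at the same aromatic carbon: a 1.6-fold lower number from compound 1 to compound 2 (0.21 log units; within the scatter), with pyridin-3-yl in place of 1-methyl-1H-pyrazol-4-yl. That single step gives little basis for a direction, so no step beyond the scatter is expected in this assay. The estimated step is a 1.0-fold higher number from compound 2 to compound 3 (0.01 log units; within the scatter). Compound 3 is expected at 0.1 h, with an estimated range from 0.05 h to 0.22 h.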

Compound 3, half-life: 0.408 h
For compound 3 the middle estimate is 4.1-fold (0.61 log units) below the measured one, outside the stated range (above it).
By their numbers in this assay, from the lowest: compounds 2 and 1 (each within the scatter of the next); then compound 3.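

In this assay the aromatic carbon ortho to a large group now shows a step beyond the scatter, which compound 1 and compound 2 alone did not show: thiophen-3-yl in place of pyridin-3-yl gives a 4.2-fold higher number from compound 2 to compound 3 (0.63 log units; beyond the scatter) on the shared core. Thiophen-3-yl in place of 1-methyl-1H-pyrazol-4-yl gives a 2.6-fold higher number from compound 1 to compound 3 (0.41 log units; beyond the scatter) at the same place, so compound 3 stands apart from both others, while those two remain within the scatter of each other. No measurement at hand explains this separation.

The three groups shown do not settle whether the sulfur atom or the ring as a whole goes with the longer half-life. Phenyl, furan-3-yl and thiophen-2-yl at this carbon remain open, as does any change elsewhere on the thiophen-3-yl compound.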